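Moving the Furan Attachment Point on a Nucleoside Core

The source may hold more compounds than are shown below. What is called first, only, known or untested is meant among the compounds shown, and "the series" means these compounds.

Measured in a functional assay on CEM-DNR-bulk cells (Homo sapiens), read by MTT assay, with a stated time of 72 h; a lower number here means a stronger inhibitor, a higher number a weaker inhibitor:
Compound 1 `COc1nc(N)nc2c1c(-c1cc3ccccc3o1)cn2[C@@H]1O[C@H](CO)[C@@H](O)[C@H]1O` gives 16700 nM.
Compound 2 `COc1ncnc2c1c(-c1ccco1)cn2[C@@H]1O[C@H](CO)[C@@H](O)[C@H]1O` gives 160 nM.
Compound 3 `COc1nc(N)nc2c1c(-c1ccoc1)cn2[C@@H]1O[C@H](CO)[C@@H](O)[C@H]1O` gives only a limit, > 20000 nM.

Compound 3 stands at the edge of what this assay can report: its value is a limit rather than a number, one of the cases at the limit of > 20000 nM in this assay, at which 1 of the 3 values shown sits. Compound 1, which differs from compound 3 only in carrying a 1-benzofuran-2-yl group instead of furan-3-yl, does give a number, and the step of an at least 1.1-fold higher number from compound 1 to compound 3 (0.07 log units; that floor lies within the scatter) is small enough to sit within the usual scatter. Compound 2 carries a furan-2-yl group and lacks the amino group that compounds 1 and 3 share, and in this assay compound 2 gives a far lower number than compound 1.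

Compound 4 `COc1nc(N)nc2c1c(-c1ccco1)cn2[C@@H]1O[C@H](CO)[C@@H](O)[C@H]1O` has not been measured. It differs from compound 3 by the change (furan-2-yl in place of furan-3-yl on an aromatic carbon). Going by the values given here, no measured step covers exactly this change. Among the compounds with values here, the only measured step, an at least 1.1-fold higher number from compound 1 to compound 3 (0.07 log units; that floor lies within the scatter), shows two weak compounds that both carry the amino group, while compound 2 shows that a furan-2-yl compound without it can be potent. Compound 4 is therefore expected to give about 3000 nM in this assay, within a wide range from 300 nM to 20000 nM. The expected step is then an at least 6.6-fold lower number from compound 3 to compound 4 (0.82 log units; beyond the scatter).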

Compound 4, half-maximal inhibitory concentration: > 20000 nM
Compound 4 was reported as a limit (the forecaster's own chance of this, stated with the estimate: 25%); middle value at least 6.6-fold (0.82 log units) away from the limit.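

In this assay compound 4 also gives only a limit, so the step between the furan-3-yl and furan-2-yl compounds cannot be read, and the two share the same ceiling: the limit of > 20000 nM in this assay, at which 2 of the 4 values shown sit.

Going by these compounds alone, with furan-2-yl held fixed, amino in place of hydrogen on an aromatic carbon gives an at least 120-fold higher number from compound 2 to compound 4 (2.09 log units; beyond the scatter), so for the first time a single change separates a measured low number from a limit. Replacing 1-benzofuran-2-yl with furan-2-yl gives an at least 1.1-fold higher number from compound 1 to compound 4 (0.07 log units; that floor lies within the scatter), and since that floor lies within the scatter, the compounds carrying the amino group show no clear separation by the group at this position.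

Going by these compounds, the limits hide how weak compound 3 and compound 4 really are, so whether the furan attachment point matters at all in the presence of the amino group stays open. Also open, on these data alone, is what a methyl or a methylamino group would give in place of the amino group, and whether furan-3-yl without the amino group would give a low number like compound 2.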